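The source may report more compounds than this note shows. Statements on the series, on what has been measured and on what is new or still open speak of the compounds shown alone.

Compound 1 `O=C(O)Cc1sc(C(c2ccccc2)c2ccc(F)c(F)c2)nc1-c1ccc(F)cc1` is the reference point of this account. In an in vitro functional assay on HEK285-7 cells for antagonist activity at prostaglandin D2 receptor 2 (Homo sapiens), read by BRET and beta-arrestin recruitment (a higher number here means a weaker inhibitor, a lower number a stronger inhibitor), compound 1 gives 64 nM, the lowest of the two numbers shown. Compound 3 `O=C(O)Cc1sc(NC(=O)c2ccccc2)nc1-c1ccc(Cl)cc1` gives 870 nM in this assay, a gap beyond the usual scatter. Compound 2 `Cc1cc(-c2nc(C(c3ccc(F)cc3)c3ccc(F)cc3)sc2CC(=O)O)cnc1N` reaches only a limit of this assay, > 100000 nM, which is the limit of > 100000 nM in this assay, at which 1 of the 3 values shown sits.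

Compound 4 `O=C(O)Cc1sc(C(c2ccccc2)c2ccc(Cl)cc2)nc1-c1ccc(F)cc1` has not yet been measured. It differs from compound 1 in one place: 4-chlorophenyl in place of 3,4-difluorophenyl on a saturated chain carbon bound to two aromatic carbons. Within the data shown here, with no measured step of this kind to draw on, the size of the change is expected to stay within the scatter, with no clear direction. Compound 4 is therefore estimated at 80 nM in this assay, between 30 nM and 250 nM, a step of a 1.3-fold higher number from compound 1 to compound 4 (0.10 log units; within the scatter) expected.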

Compound 4, half-maximal inhibitory concentration: 79 nM
The estimate for compound 4 lay 1.0-fold (0.01 log units) above the measured number, within the range that was stated.
By their numbers in this assay, from the lowest: compounds 1 and 4 (each within the scatter of the next); then compound 3. At a limit, above all of these: compound 2.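

Putting 4-chlorophenyl in place of 3,4-difluorophenyl on a saturated chain carbon bound to two aromatic carbons gives a 1.2-fold higher number from compound 1 to compound 4 (0.09 log units; within the scatter) in this assay, the first step read at this place. Here, the two halogen-bearing phenyl groups cannot be told apart, so this change of halogens leaves the number without a clear shift. Nothing measured bears on why the two groups read alike. Still open, on these data alone, is whether an amine or a carboxylic acid at this place would keep the number, and whether a longer chain would be tolerated there.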